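Compound 3 and the cytotoxicity limit

This account rests on a few compounds, and the source may have more. Where it says the series, first, only, none or still open, it means among the compounds named here.

In an ADME assay on MDBK cells (Bos taurus) for cytotoxicity (a higher number here means that more compound is tolerated, a lower number that less compound is tolerated), compound 1 `Fc1ccc(Cn2ccc3nc(-c4ccccc4)nc-3c2)cc1` gives > 100000 nM, which is a limit and not a number. Compound 2 `N#Cc1ccccc1Cn1ccc2nc(-c3ccccc3)nc-2c1` gives > 100000 nM, which is likewise a limit. Both compounds therefore stand at the limit of > 100000 nM in this assay, at which 2 of the 2 values shown sit. Going by the values given here, the only measured step is a step that the two limits leave unreadable from compound 1 to compound 2, so it offers no size to carry forward.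

Compound 3 `Clc1ccc(Cn2ccc3nc(-c4ccccc4)nc-3c2)cc1Cl` differs from compound 2 by one change: 3,4-dichlorophenyl in place of 2-cyanophenyl on a saturated chain carbon bound to an aromatic nitrogen. With no readable step as a guide, only a weak expectation can be formed in this assay: a small shift toward less compound tolerated, with a further limit quite possible. The expected step is an at least 1.2-fold lower number from compound 2 to compound 3 (0.09 log units; that floor lies within the scatter). Compound 3 is estimated at 80000 nM, with an expected range from 30000 nM to 100000 nM.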

Compound 3, half-maximal cytotoxic concentration: 71000 nM
Beside the measured number, compound 3's estimate is 1.1-fold (0.05 log units) above it; the measured number falls inside the stated range.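

At this place, on a saturated chain carbon bound to an aromatic nitrogen, 3,4-dichlorophenyl gives a readable number in this assay, which neither earlier group did. Against 2-cyanophenyl the change reads as an at least 1.4-fold lower number from compound 2 to compound 3 (0.14 log units; that floor lies within the scatter), and against 4-fluorophenyl it reads as an at least 1.4-fold lower number from compound 1 to compound 3 (0.14 log units; that floor lies within the scatter). Both steps are only floors, so the true size of each stays unknown, and the values of the other two compounds remain limits and not numbers: the limit of > 100000 nM in this assay, at which 2 of the 3 values shown sit.

The compounds shown do not tell how large either step really is, or whether the tolerated amount in this assay depends on the chlorine atoms themselves or on the pattern of substitution. They also leave open what an amine or a carboxylic acid on the phenyl ring, or a longer chain on the aromatic nitrogen, would do to this number.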